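Removing a Second Methoxy Group from Compound 2

The source may hold more compounds than are shown below. What is called first, only, known or untested is meant among the compounds shown, and "the series" means these compounds.

Compound 2 `COc1ccc(-c2cc(/C=C/C(=O)c3ccc(N)cc3)[nH]n2)cc1OC` gives -13% in a functional assay on SR cells (Homo sapiens) for cytotoxicity, read by sulforhodamine B assay, with a stated time of 48 h, tested at 10 uM; a lower number here means a stronger effect, a higher number a weaker effect of the compound at the concentration tested. Compound 1 `COc1cc(-c2cc(/C=C/C(=O)c3ccc(N)cc3)[nH]n2)cc(OC)c1OC` gives -18% in this assay, and the two numbers lie within the scatter of each other, the step being a number 5 percentage points higher from compound 1 to compound 2 (within the scatter). Compound 3 `COc1ccc(-c2cc(/C=C/C(=O)c3ccc(N)cc3)[nH]n2)cc1` differs from compound 2 by hydrogen in place of methoxy on an aromatic carbon. Within the data shown here, the one step that bears on this, from compound 1 to compound 2, also removed a methoxy group and stayed within the scatter. The step of a number 2 percentage points lower from compound 2 to compound 3 (within the scatter) is therefore expected to stay within the scatter as well. Compound 3 is expected to give -15% in this assay, with a range from -30% to 0%.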

Compound 3, a percentage reported as activity, at one concentration (the size of the read-out at that concentration, not a potency): -12%
Compound 3: the middle estimate sits 3 percentage points below what was measured; low and high end bracket the measured number.
By their numbers in this assay, from the lowest: compounds 1, 2 and 3 (each within the scatter of the next).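

Replacing this methoxy group, ortho to a methoxy group, with hydrogen gives a number 1 percentage points higher from compound 2 to compound 3 (within the scatter) in this assay, so this place tolerates the change with no difference beyond the scatter. Compounds 1, 2 and 3 now form a series in which each lies within the scatter of the next, even as methoxy groups leave the aromatic ring. Nothing measured here explains this result.

The compounds shown leave open what happens when the remaining methoxy group is replaced by hydrogen. They also leave open whether an amine or a carboxylic acid at that place would give a number beyond the scatter.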